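This account rests on a few compounds, and the source may have more. Where it says the series, first, only, none or still open, it means among the compounds named here.

In an ADME assay on MT4 cells (Homo sapiens) for cytotoxicity, read by MTT assay, with a stated time of 96 h (a lower number here means that less compound is tolerated, a higher number that more compound is tolerated), compound 3 `NS(=O)(=O)c1ccc(N2N=C(c3ccc(Oc4ccccc4)cc3)CC2c2cccc(Cl)c2)cc1` gives 8000 nM, the lower of the two actual numbers in the series. Compound 2 `NS(=O)(=O)c1ccc(N2N=C(c3ccc(Oc4ccccc4)cc3)CC2c2ccccc2)cc1` gives 42000 nM. Compound 1 `Cc1ccccc1C1CC(c2ccc(OCc3ccccc3)cc2)=NN1c1ccc(S(N)(=O)=O)cc1` reads >= 100000 nM, which is a limit of the assay and not a number. Compound 4 `Cc1ccccc1C1CC(c2ccc(Oc3ccccc3)cc2)=NN1c1ccc(S(N)(=O)=O)cc1` differs from compound 3 as follows: 2-methylphenyl in place of 3-chlorophenyl on a saturated ring carbon, with 2-methylphenyl in place of 3-chlorophenyl on a saturated ring carbon. Going by the values given here, the only measured step that bears on this change is a 5.3-fold lower number from compound 2 to compound 3 (0.72 log units; beyond the scatter), with chloro in place of hydrogen on an aromatic carbon. Compound 4 has no chloro, and compound 1 carries the same 2-methylphenyl, so a modest rise is expected, largely undoing that step. The expected change in this assay is a 3.8-fold higher number from compound 3 to compound 4 (0.57 log units; beyond the scatter). For compound 4 the estimated value is 30000 nM, with an expected range of 10000 nM to 100000 nM.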

Compound 4, half-maximal cytotoxic concentration: 36000 nM
For compound 4 the middle estimate is 1.2-fold (0.08 log units) below the measured one; the measured number falls inside the stated range.
By their numbers in this assay, from the lowest: compound 3; then compounds 4 and 2 (each within the scatter of the next). At a limit, above all of these: compound 1.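

In this assay, a methyl on this phenyl does not do what the chloro did: replacing the 3-chlorophenyl with 2-methylphenyl gives a 4.5-fold higher number from compound 3 to compound 4 (0.65 log units; beyond the scatter), while adding the methyl to the plain phenyl gives a 1.2-fold lower number from compound 2 to compound 4 (0.07 log units; within the scatter). Of the compounds shown, only the 3-chlorophenyl compound stands apart at this position. With the 2-methylphenyl held, the group on the oxygen also counts, though this step starts from a limit, not a number, an at least 2.7-fold lower number from compound 1 to compound 4 (0.44 log units; beyond the scatter): the limit of >= 100000 nM in this assay, at which 1 of the 4 values shown sits.

Going by these compounds, it stays open whether the lower number follows from the chloro itself or from where it sits on the phenyl. On these data alone, how a methoxy or an amine on this phenyl would read also stays open.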